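The source may hold more compounds than are shown below. What is called first, only, known or untested is meant among the compounds shown, and "the series" means these compounds.

Of the compounds shown here, three built on one shared core have been tested in a functional assay on NCI-H460 cells (Homo sapiens) for inhibition, read by sulforhodamine B assay, with a stated time of 48 h; on this read-out lower numbers stand for higher toxicity in this test and higher numbers for lower toxicity in this test. Compound 1 `Nc1cc(N)c2nc(-c3ccccc3)c(NCc3ccc(Cl)c(Cl)c3)nc2c1` gives only a limit of the assay, < 100000 nM. Compound 2 `COc1ccc(CNc2nc3cc(N)cc(N)c3nc2-c2ccccc2)cc1OC` likewise gives a limit, < 100000 nM. Compound 3 `CCOC(=O)[C@H](CCC(=O)O)NC(=O)c1ccc(Sc2nc3cc(N)cc(N)c3nc2-c2ccccc2)cc1` also gives a limit, < 100000 nM. The step from compound 1 to compound 2 (a step that the two limits leave unreadable from compound 1 to compound 2) cannot be read because the limit of < 100000 nM in this assay, at which 3 of the 3 values shown sit, is where all three values sit. Compound 4 `COc1cc(CNc2nc3cc(N)cc(N)c3nc2-c2ccccc2)cc(OC)c1OC` differs from compound 2 by methoxy in place of hydrogen on an aromatic carbon. With every measured value a limit, no size or direction can be drawn for this change. Compound 4 is therefore expected to sit near the same limit, an estimated step that the limit leaves unreadable from compound 2 to compound 4. The estimate for compound 4 in this assay is 30000 nM, within a range from 3000 nM to 100000 nM.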

Compound 4, concentration lethal to 50% of the cells: < 50200 nM
Compound 4: only a limit was reported; the forecaster's own chance of this, stated with the estimate: 60%; the middle value is on the limit's open side.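

For the compounds shown here, compound 2 and compound 4 both give only limits in this assay, and no step between them can be read. Going by these compounds, whether methoxy in place of hydrogen on an aromatic carbon changes the read-out at all, and where any of the four compounds truly lies, stays open.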